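Cytotoxicity notes: compound 3 from compound 2

This account rests on a few compounds, and the source may have more. Where it says the series, first, only, none or still open, it means among the compounds named here.

Measured in an ADME assay on MCF-10A cells (Homo sapiens) for cytotoxicity, read by sulforhodamine B assay, with a stated time of 72 h, tested at 10 uM; a higher number here means a stronger effect of the compound at the concentration tested, a lower number a weaker effect:
compound 1 `COc1cccc(C(=O)CC2C(C#N)=C(N)Oc3c(OC)cc(Br)cc32)c1` gives 32.3%
compound 2 `COc1cccc(C(=O)CC2C(C#N)=C(N)Oc3ccc(Br)cc32)c1` gives 101%

Among the measured compounds shown here, compound 2 stands highest of the two numbers; the only measured step, a number 68.7 percentage points higher from compound 1 to compound 2 (beyond the scatter), is hydrogen in place of methoxy on an aromatic carbon of the shared core. Compound 3 `Cc1ccc(C(=O)CC2C(C#N)=C(N)Oc3ccc(Br)cc32)cc1` differs from compound 2 by 4-methylphenyl in place of 3-methoxyphenyl on a carbonyl carbon. For the measured compounds named here, no measured step touches the aryl ketone, so the step from compound 1 to compound 2 bears only indirectly, showing the series can swing widely. The step to compound 3 is expected to be a number 16 percentage points lower from compound 2 to compound 3 (beyond the scatter) in this assay, a modest decrease at most. Compound 3 is estimated at 85%, range 40% to 105%.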

Compound 3, a percentage reported as activity, at one concentration (the size of the read-out at that concentration, not a potency): 133%
Estimate against measurement, compound 3: 48 percentage points below; the whole stated range lies below it.
By their numbers in this assay, from the lowest: compound 1; then compound 2; then compound 3.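

The aryl ketone proves to be a sensitive position in this assay: 4-methylphenyl in place of 3-methoxyphenyl on a carbonyl carbon gives a number 32 percentage points higher from compound 2 to compound 3 (beyond the scatter), so large steps are not confined to the methoxy on the shared core. This single step changes both the group on the aryl ring and where it sits, so neither change can be credited alone. No evidence at hand bears on why the number rises. Open, as far as these compounds go, is whether an amine or a carboxylic acid on that ring would keep the number this high. Also open, from the compounds shown here alone, is whether restoring the core methoxy would pull compound 3 down as far as compound 1 stands from compound 2.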